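Lengthening the diamine chain on a piperazine amide

A few compounds are considered here, and "the series" means these few. Any claim that something is new, unique, unknown or untested is made for them only; others in the source may bear on it.

Measured compounds and their values:
compound 1 `NCC(N)CCCCNC(=O)c1cc(O)c(O)c(O)c1` gives 93.8%
compound 2 `CC(C)(C)OC(=O)NCC(CCCCNC(=O)CCn1cccc(O)c1=O)NC(=O)OC(C)(C)C` gives 90%
compound 3 `NCC(N)CC(=O)N1CCN(C(=O)CCn2cccc(O)c2=O)CC1` gives 75.1%

In a physicochemical assay, read by spectrophotometry, with a stated time of 10 min, tested at 1 mM, in the presence of a further agent that is not named here (a higher number here means a stronger effect of the compound at the concentration tested, a lower number a weaker effect), compound 3 stands lowest of the numbers shown. Compound 2 sits closest to it, and its value lies beyond the scatter above compound 3; compound 1 sits furthest away, also beyond the scatter. No pair among these three differs in only one place, so no single step between measured compounds can be read from them.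

Compound 4 `NCC(N)CCC(=O)N1CCN(C(=O)CCn2cccc(O)c2=O)CC1` differs from compound 3 in one place: 2,3-diaminopropyl in place of 1,2-diaminoethyl on a saturated chain carbon bound to a carbonyl carbon. The carbonyl, the piperazine ring and the hydroxypyridinone part are kept unchanged; only the saturated chain carrying the two amines grows by one carbon.

The change is a small one within the chain named above, and a step of little size is expected, a number 0.1 percentage points lower from compound 3 to compound 4 (within the scatter), not beyond the scatter in either direction. For compound 4 the expected value is 75%, with a range from 62% to 88%.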

Compound 4, a percentage reported as activity, at one concentration (the size of the read-out at that concentration, not a potency): 74.6%
Compound 4: middle estimate off by 0.4 percentage points, on the high side, within the range that was stated.
By their numbers in this assay, from the lowest: compounds 4 and 3 (each within the scatter of the next); then compounds 2 and 1 (each within the scatter of the next).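

In this assay, among the compounds shown here, putting 2,3-diaminopropyl in place of 1,2-diaminoethyl on a saturated chain carbon bound to a carbonyl carbon gives a number 0.5 percentage points lower from compound 3 to compound 4 (within the scatter), the first comparison here in which only one place differs. At this position, then, adding one carbon to the saturated chain that carries the two amines leaves a step within the scatter, so this assay does not separate the two chains. No measurement shown here offers an explanation for this result.

Still open, as far as these compounds go, is whether a longer chain carrying the same two amines, or a chain with a single amine or a carboxylic acid at this place, would give a step beyond the scatter. Steps linking compound 1 or compound 2 to this pair cannot be read, as each differs from compound 3 and compound 4 in more than one place.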